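Methyl on the chain carbon: from amide to amine series

The source may report more compounds than this note shows. Statements on the series, on what has been measured and on what is new or still open speak of the compounds shown alone.

Compound 1 `CN(Cc1ccccc1)Cc1ccc[nH]1` is a simple amine, and in an assay on mitochondria for inhibition of Amine oxidase [flavin-containing] B (Bos taurus), read by fluorescence (on this read-out lower numbers stand for stronger inhibition and higher numbers for weaker inhibition), compound 1 gives 20 nM, the lowest number of the three measured compounds. Compound 2 `CN(Cc1ccccc1)C(=O)c1ccc[nH]1` carries a carbonyl in place of the chain carbon next to the ring-bearing carbon, and in this assay compound 2 gives 150000 nM; how the two cores differ is not broken down here. Compound 3 `CC(c1ccccc1)N(C)C(=O)c1ccc[nH]1` adds one carbon to compound 2, namely (methyl in place of hydrogen on a saturated chain carbon bound to an amide-type nitrogen and an aromatic carbon), and in this assay compound 3 gives 4500 nM. That single change produced a 33-fold lower number from compound 2 to compound 3 (1.52 log units; beyond the scatter).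

Compound 4 `CC(c1ccccc1)N(C)Cc1ccc[nH]1` has not yet been measured. It stands to compound 1 as compound 3 stands to compound 2: the change is methyl in place of hydrogen on a saturated chain carbon bound to an amine nitrogen and an aromatic carbon. The two places are not identical, since in compound 3 the carbon is bound to an amide-type nitrogen and in compound 4 to an amine nitrogen, so this is the same kind of change, not the same change. Because the earlier step gave a 33-fold lower number from compound 2 to compound 3 (1.52 log units; beyond the scatter), a move in the same direction is expected, though smaller, since compound 1 already starts far lower; the expected step is a 3.3-fold lower number from compound 1 to compound 4 (0.52 log units; beyond the scatter). Compound 4 is therefore estimated to give 6 nM in this assay, expected to fall between 1 nM and 40 nM.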

Compound 4, inhibition constant: 1500 nM
For compound 4 the middle estimate is 250-fold (2.40 log units) below the measured one; measured number above the stated range.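

In this assay, the methyl in place of hydrogen on the chain carbon did not carry over from one core to the other: the step of a 75-fold higher number from compound 1 to compound 4 (1.88 log units; beyond the scatter) runs opposite to the step of a 33-fold lower number from compound 2 to compound 3 (1.52 log units; beyond the scatter) on the core of compound 2. Set side by side, the two steps differ in direction and by far more than repeat measurements would explain: the same change on two cores in this assay, a 33-fold lower number (1.52 log units; beyond the scatter) from compound 2 to compound 3 and a 75-fold higher number (1.88 log units; beyond the scatter) from compound 1 to compound 4, 2500-fold (3.40 log units) apart, beyond the scatter of two such steps. This shows that, in these two pairs, the effect of the methyl depends on the core that carries it, so a step measured on one core was a poor guide to the other, but it does not show why, and two pairs give no rule for the whole series.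

The compounds shown leave open how an ethyl group or a longer chain in the same place would act on either core. They also leave open which of the two pairs, if either, the same methyl change would follow on a further core.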